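This account rests on a few compounds, and the source may have more. Where it says the series, first, only, none or still open, it means among the compounds named here.

Three compounds built on one shared core were tested in an ADME assay on MT4 cells (Homo sapiens) for cytotoxicity, read by MTT assay, with a stated time of 5 days; on this read-out lower numbers stand for higher toxicity in this test and higher numbers for lower toxicity in this test. Compound 1 `Cc1cc(C)cc(S(=O)(=O)c2c(C(=O)N[C@@H]3CCN(Cc4n[nH]c(=O)n4C)C3)[nH]c3ccc(Cl)cc23)c1` gives 22400 nM. Compound 2 `Cc1cc(C)cc(S(=O)(=O)c2c(C(=O)N[C@@H]3CCN(CC(N)=O)C3)[nH]c3ccc(Cl)cc23)c1` gives 31000 nM, and compound 3 `Cc1cc(C)cc(S(=O)(=O)c2c(C(=O)NC3CN(CC(N)=O)C3)[nH]c3ccc(Cl)cc23)c1` gives 25500 nM. Compound 1 differs from compound 2 by a group of 7 heavy atoms (3 carbon, 3 nitrogen, 1 oxygen; one five-membered aromatic ring with 3 hetero atoms) in place of a group of 3 heavy atoms (1 carbon, 1 nitrogen, 1 oxygen; no ring), on a saturated chain carbon bound to an amine nitrogen in a ring, and that change produced a 1.4-fold lower number from compound 2 to compound 1 (0.14 log units; within the scatter). Compound 3 differs from compound 2 in the core itself, namely (1-(carbamoylmethyl)azetidin-3-yl in place of 1-(carbamoylmethyl)pyrrolidin-3-yl on an amide-type nitrogen), which produced a 1.2-fold lower number from compound 2 to compound 3 (0.08 log units; within the scatter).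

Compound 4 `Cc1cc(C)cc(S(=O)(=O)c2c(C(=O)NC3CN(Cc4n[nH]c(=O)n4C)C3)[nH]c3ccc(Cl)cc23)c1` has not yet been measured in this assay. Going by the values given here, it carries the core of compound 3 and differs from compound 3 by a group of 7 heavy atoms (3 carbon, 3 nitrogen, 1 oxygen; one five-membered aromatic ring with 3 hetero atoms) in place of a group of 3 heavy atoms (1 carbon, 1 nitrogen, 1 oxygen; no ring), on a saturated chain carbon bound to an amine nitrogen in a ring, which is the same change, in the same place, as the one leading from compound 2 to compound 1. A step of similar size is expected here, namely a 1.3-fold lower number from compound 3 to compound 4 (0.11 log units; within the scatter), because the earlier step of a 1.4-fold lower number from compound 2 to compound 1 (0.14 log units; within the scatter) stayed within the scatter of the measurement. Compound 4 is accordingly estimated at 20000 nM, with the expected range reaching from 10000 nM to 40000 nM.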

Compound 4, half-maximal cytotoxic concentration: 25200 nM
For compound 4 the middle estimate is 1.3-fold (0.10 log units) below the measured one, within the range that was stated.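

In this assay, putting the group with the five-membered aromatic ring in place of carbamoyl gives a 1.0-fold lower number from compound 3 to compound 4 (0.01 log units; within the scatter), and this step agrees with the one seen on the other core: the same change on two cores in this assay, a 1.4-fold lower number (0.14 log units; within the scatter) from compound 2 to compound 1 and a 1.0-fold lower number (0.01 log units; within the scatter) from compound 3 to compound 4, 1.4-fold (0.14 log units) apart, within the scatter of two such steps The step that alters the ring on the amide-type nitrogen and the end group together, a 1.2-fold lower number from compound 2 to compound 4 (0.09 log units; within the scatter), also stays within the scatter. This shows that the change left no readable mark on this cytotoxicity read-out on either core, but two steps this small cannot show that it has a fixed size, and they say nothing about other cores or other assays.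

The compounds shown leave open whether any group on this saturated chain carbon would give a step beyond the scatter, for example a simple amine, a carboxylic acid or a longer chain ending in carbamoyl. They also leave open whether the same exchange would stay this small on a core with a six-membered ring on the amide-type nitrogen.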